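From Methyl to Fluoro on a Weakly Active Amide

The source may report more compounds than this note shows. Statements on the series, on what has been measured and on what is new or still open speak of the compounds shown alone.

The study measures an ADME assay on cells for inhibition of cytochrome P450 11B1, mitochondrial (Homo sapiens), read by HTRF; a lower number here means a stronger inhibitor, a higher number a weaker inhibitor. Compound 1, `CCC(=O)N[C@@H]1CCCc2c1cncc2N1C(=O)c2ccc(Cl)cc2[C@@H]1C`, gives 414 nM in this assay. Compound 2, `Cc1cc(Cl)ccc1C(=O)Nc1cccnc1`, reaches only the limit of the assay, > 3000 nM, in this assay. Compound 3, `Cc1cc(Cl)ccc1C(=O)N(C)c1cccnc1`, likewise reaches only the limit of the assay, > 3000 nM, in this assay. Among the measured compounds shown here, the step that the two limits leave unreadable from compound 2 to compound 3 cannot be read, the two limits leaving its size open; the only evidence bearing on it is the limit of > 3000 nM in this assay, at which 2 of the 3 values shown sit.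

Compound 4, `CN(C(=O)c1ccc(Cl)cc1F)c1cccnc1`, differs from compound 3 in one place: fluoro in place of methyl on an aromatic carbon. For the measured compounds named here, no measured step covers a fluoro in place of methyl on an aromatic carbon, and the single step from compound 2 to compound 3 gives no readable size or direction. Where compound 3 stands is known only as a limit, so the step to compound 4 in this assay cannot be expected to show a size or direction beyond the scatter. Compound 4 is therefore expected to stay near that limit, with the expected step that the limit leaves unreadable from compound 3 to compound 4 in this assay. The estimate for compound 4 in this assay is 5000 nM, between 2500 nM and 20000 nM, most likely reported once more as a limit rather than a number.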

Compound 4, half-maximal inhibitory concentration: > 3000 nM
Compound 4: only a limit was reported; the forecaster's own chance of this, stated with the estimate: 75%; the middle value lies beyond the limit too.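

In this assay compound 4 gives > 3000 nM, which is a limit of the assay and not a number. Compound 3 also stands at a limit, so no step can be read from compound 3 to compound 4: the limit of > 3000 nM in this assay, at which 3 of the 4 values shown sit.

The compounds shown leave open whether fluoro in place of methyl on an aromatic carbon shifts the result in this assay at all.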